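The compounds below may be only part of what the source reports. "The series", "measured", "known", "first", "only" and "open" are said of these compounds alone.

Compound 1 `O=C(CCCc1ccccc1)Nc1nc2ccc(Cl)cc2c(=O)s1`: > 10000 nM
Compound 2 `O=C(CCCc1cccc(Cl)c1)Nc1nc2ccccc2c(=O)s1`: 898 nM

Two compounds share the same core and carry a chloro in different places. In an assay on membranes from brain for displacement of a labelled ligand from adenosine receptor A1 (Rattus norvegicus), read by scintillation counting, with a stated time of 90 min (on this read-out lower numbers stand for stronger inhibition and higher numbers for weaker inhibition), compound 1 gives only a limit, > 10000 nM, which marks the edge of what the measurement reports and is not a number. In this assay compound 2 gives 898 nM. For the measured compounds named here, these two differ in more than one place, so no single step between them is counted; their values show only that compound 2 yields a number where compound 1 does not.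

Compound 3 `O=C(CCCc1ccccc1)Nc1nc2ccc(Br)cc2c(=O)s1` has not yet been measured. It differs from compound 1 in one place: bromo in place of chloro on an aromatic carbon. Because compound 1 sits at the limit of > 10000 nM in this assay, at which 1 of the 2 values shown sits, the starting point is a limit rather than a number. The expected step is a number no higher from compound 1 to compound 3 (the limit leaves the size open), nothing beyond the usual scatter. Compound 3 is therefore estimated at 10000 nM, with a range from 3000 nM to 30000 nM.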

Compound 3, inhibition constant: > 10000 nM
Compound 3: a limit, no number; the forecaster's own chance of this, stated with the estimate: 60%; the middle value lies on the limit itself.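

No step can be read between compound 1 and compound 3, because each gives a limit of the assay and not a number: the limit of > 10000 nM in this assay, at which 2 of the 3 values shown sit.

The compounds shown leave open whether bromo in place of chloro on an aromatic carbon changes the inhibition constant in this assay at all.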